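This account rests on a few compounds, and the source may have more. Where it says the series, first, only, none or still open, it means among the compounds named here.

Of the compounds shown here, three sharing a common core have been tested, and a fourth awaits its result. Compound 2 `COc1ccc2nc(C)cc(SCc3ccccc3)c2c1` carries an unsubstituted benzyl group; in a functional assay on MCF-10A cells (Homo sapiens) for antiproliferative activity, with a stated time of 48 h (a higher number here means that more compound is needed for the effect, a lower number that less compound is needed), compound 2 gives 37100 nM. Compound 1 `COc1ccc2nc(C)cc(SCc3ccc(F)cc3)c2c1` differs from it by fluoro in place of hydrogen on an aromatic carbon; in this assay compound 1 gives 50500 nM, and the change a 1.4-fold higher number from compound 2 to compound 1 (0.13 log units; within the scatter). Compound 3 `COc1ccc2nc(C)cc(NCc3ccccc3F)c2c1` gives 17000 nM in this assay; how its core differs from that of compound 2 is not broken down here. Compound 4 `COc1ccc2nc(C)cc(NCc3ccc(F)cc3F)c2c1` is the not yet measured compound, differing from compound 3 by fluoro in place of hydrogen on an aromatic carbon. This is the same kind of change as that from compound 2 to compound 1, though here the new fluoro sits meta to a fluoro group as well as para to a large group. Because the earlier step of a 1.4-fold higher number from compound 2 to compound 1 (0.13 log units; within the scatter), a similar small step a 1.2-fold higher number from compound 3 to compound 4 (0.09 log units; within the scatter) is expected, giving compound 4 an estimated 21000 nM in this assay.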

Compound 4, half-maximal effective concentration: 15000 nM
Compound 4: middle estimate off by 1.4-fold (0.15 log units), on the high side; the range from low to high includes it.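

In this assay, adding the fluoro gives a 1.1-fold lower number from compound 3 to compound 4 (0.05 log units; within the scatter), so on this second core the step again stays within the scatter. Set side by side, the two steps do not differ beyond what repeated measurements would produce: the same change on two cores in this assay, a 1.4-fold higher number (0.13 log units; within the scatter) from compound 2 to compound 1 and a 1.1-fold lower number (0.05 log units; within the scatter) from compound 3 to compound 4, 1.5-fold (0.19 log units) apart, within the scatter of two such steps This suggests that the change carries over between these two cores as a small step, but two pairs cannot establish a rule for the whole series, and they do not explain why the step is small.

The compounds shown leave open whether a larger group in the same place, such as trifluoromethyl or a carboxylic acid, would give a step beyond the scatter. They also leave open how the fluoro change behaves on other cores.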